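A few compounds are considered here, and "the series" means these few. Any claim that something is new, unique, unknown or untested is made for them only; others in the source may bear on it.

Compound 3, `O=C(O)Cc1sc(C(c2ccc(F)cc2)c2ccc(F)cc2)nc1-c1ccccc1`, stands at the top of the three numbers seen so far: in an in vitro functional assay on HEK285-7 cells for antagonist activity at prostaglandin D2 receptor 2 (Homo sapiens), read by BRET and beta-arrestin recruitment (a lower number here means a smaller maximal response, a higher number a larger maximal response), compound 3 gives 80%, while compound 2, `NS(=O)(=O)c1cccc(-c2nc(C(c3ccc(F)cc3)c3ccc(F)cc3)sc2CC(=O)O)c1`, gives 55% and compound 1, `Nc1cc(-c2nc(C(c3ccc(F)cc3)c3ccc(F)cc3)sc2CC(=O)O)cc(F)n1`, gives 30%. The step of a number 25 percentage points higher from compound 2 to compound 3 (beyond the scatter) and the step of a number 50 percentage points higher from compound 1 to compound 3 (beyond the scatter) both lead upward to compound 3, and the step of a number 25 percentage points higher from compound 1 to compound 2 (beyond the scatter) lies between the two.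

Compound 4, `CN(C)c1cc(-c2nc(C(c3ccc(F)cc3)c3ccc(F)cc3)sc2CC(=O)O)ccn1`, differs from compound 3 in one place: 2-(dimethylamino)pyridin-4-yl in place of phenyl on an aromatic carbon. Among the measured compounds shown here, the steps that bear on this change are those that exchanged the phenyl for a substituted aryl, above all a number 50 percentage points higher from compound 1 to compound 3 (beyond the scatter), where a 2-amino-6-fluoropyridin-4-yl group stood in place of phenyl, and a number 25 percentage points higher from compound 2 to compound 3 (beyond the scatter). Read in reverse, both point downward, so a step of modest to large size downward in this assay is expected for compound 4. The estimate for compound 4 is therefore 45%, within a range from 25% to 70%, which means an expected step of a number 35 percentage points lower from compound 3 to compound 4 (beyond the scatter).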

Compound 4, largest response reached (reported as efficacy), in percent of the reference or control that the assay uses: 80%
For compound 4 the middle estimate is 35 percentage points below the measured one; the whole stated range lies below it.
By their numbers in this assay, from the lowest: compound 1; then compound 2; then compounds 3 and 4 (each within the scatter of the next).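

In this assay, the step from phenyl to a pyridine ring with a dimethylamino group is flat: no change at the digits printed from compound 3 to compound 4 (within the scatter). Its effect depends on the substituents, as the 2-(dimethylamino)pyridin-4-yl group and the 2-amino-6-fluoropyridin-4-yl group both carry a pyridine ring at this position yet differ clearly, with a number 50 percentage points higher from compound 1 to compound 4 (beyond the scatter). The earlier lowering with a substituted aryl group therefore does not extend to every such group, since a number 25 percentage points higher from compound 2 to compound 4 (beyond the scatter) and compound 4 stands level with unsubstituted compound 3.

Whether the fluorine or the primary amine of compound 1 accounts for its lower number stays open, as does the effect of a dimethylamino group on a phenyl ring. No measurement shown here explains the difference between the two pyridine groups.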